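This account rests on a few compounds, and the source may have more. Where it says the series, first, only, none or still open, it means among the compounds named here.

Compound 1 `O=CCc1c(-c2ccccc2Cl)c2cc(Cl)ccc2[nH]c1=O`: 120000 nM
Compound 2 `CC(=O)NCC(=O)OCCc1c(-c2ccccc2Cl)c2cc(Cl)ccc2[nH]c1=O`: 110000 nM

For the measured compounds named here, in an ADME assay on HepG2 2.2.15 cells (Homo sapiens) for cytotoxicity (a lower number here means that less compound is tolerated, a higher number that more compound is tolerated), compound 2 stands at the lowest of the two numbers, though compound 1 sits within the scatter of it, as the only measured step shows: a 1.1-fold lower number from compound 1 to compound 2 (0.04 log units; within the scatter). Compound 3 `O=C(OCCc1c(-c2ccccc2Cl)c2cc(Cl)ccc2[nH]c1=O)c1cccs1` differs from compound 2 in one place: thiophen-2-yl in place of acetamidomethyl on a carbonyl carbon. The measured step of a 1.1-fold lower number from compound 1 to compound 2 (0.04 log units; within the scatter) changed this same end of the chain and stayed within the scatter, so for compound 3 no step beyond the scatter is expected: a 1.2-fold lower number from compound 2 to compound 3 (0.09 log units; within the scatter). Compound 3 is therefore estimated at 90000 nM, with a range from 40000 nM to 200000 nM.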

Compound 3, half-maximal cytotoxic concentration: > 1700000 nM
Compound 3 was reported as a limit (the forecaster's own chance of this, stated with the estimate: 15%); middle value at least 18-fold (1.27 log units) from the limit.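

In this assay, the group on the carbonyl carbon can shift the number well beyond the scatter, which the earlier step along this chain did not show: thiophen-2-yl in place of acetamidomethyl gives an at least 15-fold higher number from compound 2 to compound 3 (1.18 log units; beyond the scatter). Set against the formyl end of compound 1, the full (((thiophen-2-yl)carbonyl)oxy)methyl group gives an at least 14-fold higher number from compound 1 to compound 3 (1.15 log units; beyond the scatter). The value of compound 3 is a limit, so the full size of both steps stays unknown: the limit of > 1700000 nM in this assay, at which 1 of the 3 values shown sits.

As far as these compounds go, whether a phenyl ring, a furan-2-yl ring or a plain methyl on the same carbonyl carbon would give a similar shift remains open.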